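Cyclopropyl in Place of Ethyl: an Expected Growth Result

The source may report more compounds than this note shows. Statements on the series, on what has been measured and on what is new or still open speak of the compounds shown alone.

Compound 1 `COC(=O)c1nc(C)n(-c2cccc(Br)c2)n1`: > 100000 nM
Compound 2 `CCc1nc(C(=O)OC)nn1-c1ccc(F)cc1`: 15800 nM

In a functional assay on NPC-TW01 cells (Homo sapiens) for inhibition, read by MTT assay, with a stated time of 72 h (a higher number here means a weaker inhibitor of growth, a lower number a stronger inhibitor of growth), compound 1 is reported only as a limit of the assay, > 100000 nM, not as a number (the limit of > 100000 nM in this assay, at which 1 of the 2 values shown sits). In this assay compound 2 gives 15800 nM, the only number shown, so compound 2 stands alone among the figures. Compound 3 `COC(=O)c1nc(C2CC2)n(-c2ccc(F)cc2)n1` differs from compound 2 by cyclopropyl in place of ethyl on an aromatic carbon. Within the data shown here, no measured step resembles this change; the step is expected to be small, within the usual scatter, leaning toward stronger inhibition: a 1.3-fold lower number from compound 2 to compound 3 (0.12 log units; within the scatter). Compound 3 is estimated at 12000 nM, between 4000 nM and 40000 nM.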

Compound 3, concentration for 50% growth inhibition: 95900 nM
Beside the measured number, compound 3's estimate is 8.0-fold (0.90 log units) below it; the measured number lies above the stated range.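

In this assay, this position proves sensitive to the group it carries: cyclopropyl in place of ethyl on an aromatic carbon gives a 6.1-fold higher number from compound 2 to compound 3 (0.78 log units; beyond the scatter). Compound 1 and compound 2 differ in more than one place, so they could not show what a change at this position alone does. Nothing measured here explains the step.

From the compounds shown here alone, it remains open whether a longer chain such as propyl, or an amine, at this position would behave like ethyl or like cyclopropyl. Going by these compounds, whether a carboxylic acid in place of the methoxycarbonyl group would change this step also remains open.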